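This account rests on a few compounds, and the source may have more. Where it says the series, first, only, none or still open, it means among the compounds named here.

Compound 1 `COc1ccc(C2=C(c3cc(OC)c(OC)c(OC)c3)C(=O)C(O)C2)cc1`: < 1 ug/mL
Compound 2 `COc1ccc(C2=C(c3cc(OC)c(OC)c(OC)c3)C(=O)C(OC(C)=O)C2)cc1F`: < 1 ug/mL

Both compounds were tested in an ADME assay on HEp-2 cells (Homo sapiens) for cytotoxicity, read by MTT assay, with a stated time of 72 h (a higher number here means a weaker inhibitor, a lower number a stronger inhibitor), and neither has a number there. Compound 2 stands at < 1 ug/mL, which is a limit of the assay and not a number. Compound 1 gives < 1 ug/mL, which is also a limit. Among the compounds with values here, the record so far therefore comes down to the limit of < 1 ug/mL in this assay, at which 2 of the 2 values shown sit, and it gives no measured step between compounds.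

Compound 3 `COc1ccc(C2=C(c3cc(OC)c(OC)c(OC)c3)C(=O)C(O)C2)cc1F` differs from compound 2 in one place: hydrogen in place of acetyl on an oxygen on a saturated carbon. The change is hydrogen in place of acetyl on an oxygen on a saturated carbon, which reads as acetoxy to hydroxy when cut one bond further out.

With compound 2 at the limit of < 1 ug/mL, no step beyond the scatter is expected in this assay, though the data cannot fix its size. The expected change, a step that the limit leaves unreadable from compound 2 to compound 3, is only an estimate. Compound 3 may well be reported only as a limit too. As a number, compound 3 is estimated at 0.6 ug/mL, with an expected range of 0.1 ug/mL to 2 ug/mL.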

Compound 3, half-maximal inhibitory concentration: < 1 ug/mL
Compound 3 was reported as a limit (the forecaster's own chance of this, stated with the estimate: 75%); the middle value lies beyond the limit too.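

No step can be read between compound 1, compound 2 and compound 3 in this assay, because each is reported only as a limit and not as a number: the limit of < 1 ug/mL in this assay, at which 3 of the 3 values shown sit.

The compounds shown leave open how far either acetoxy to hydroxy or fluoro in place of hydrogen on an aromatic carbon shifts the cytotoxicity.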